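The compounds below may be only part of what the source reports. "The series", "measured", "known", "first", "only" and "open" are said of these compounds alone.

In a functional assay on CHO cells for agonist activity at Free fatty acid receptor 1 (Homo sapiens), read by calcium flux (a lower number here means that less compound is needed, a higher number that more compound is needed for the effect), the compounds shown share one core and differ only in the acid-bearing chain. Compound 1 `CO[C@H]1C[C@H](Oc2cc(F)c(F)c(-c3cc(F)c(OCCC(C)(C)C(=O)O)c(F)c3)c2)C1` gives in this assay only a limit, > 100000 nM, not a number. Compound 2 `CO[C@H]1C[C@H](Oc2cc(F)c(F)c(-c3cc(F)c(OCCCCC(=O)O)c(F)c3)c2)C1` gives 68800 nM in this assay, and compound 3 `CO[C@H]1C[C@H](Oc2cc(F)c(F)c(-c3cc(F)c(OCCCCCC(=O)O)c(F)c3)c2)C1` gives 11000 nM in this assay. Of the two numbers shown, compound 3 has the lowest; its nearest neighbour is compound 2, and the step of a 6.3-fold lower number from compound 2 to compound 3 (0.80 log units; beyond the scatter) stands beyond the scatter. The steps of an at least 1.4-fold lower number from compound 1 to compound 2 (0.16 log units; that floor lies within the scatter) and an at least 9.0-fold lower number from compound 1 to compound 3 (0.95 log units; beyond the scatter) start from the limit (the limit of > 100000 nM in this assay, at which 1 of the 3 values shown sits), so only their floors are known.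

Compound 4 `CO[C@H]1C[C@H](Oc2cc(F)c(F)c(-c3cc(F)c(OCCCCCCC(=O)O)c(F)c3)c2)C1` differs from compound 3 by carboxymethyl in place of carboxy on a saturated chain carbon, five bonds along the chain from an oxygen on an aromatic ring. For the measured compounds named here, the measured step of the same kind is a 6.3-fold lower number from compound 2 to compound 3 (0.80 log units; beyond the scatter), the one step that bears on the change directly; an at least 9.0-fold lower number from compound 1 to compound 3 (0.95 log units; beyond the scatter) points the same way but rests on a limit. A further lowering is therefore expected, without assuming that a single step repeats at full size. In this assay compound 4 is estimated at 3500 nM, between 1000 nM and 11000 nM, which is the expected step of a 3.1-fold lower number from compound 3 to compound 4 (0.50 log units; beyond the scatter).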

Compound 4, half-maximal effective concentration: 3500 nM
Estimate against measurement, compound 4: no gap at the digits printed; measured number inside the range.
By their numbers in this assay, from the lowest: compound 4; then compound 3; then compound 2. At a limit, above all of these: compound 1.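

In this assay the lowering continues when carboxymethyl replaces carboxy at this further position, with a 3.1-fold lower number from compound 3 to compound 4 (0.50 log units; beyond the scatter), so the trend now runs through compound 2, compound 3 and compound 4, and none of the three goes against it. Taken together, the chain change gives a 20-fold lower number from compound 2 to compound 4 (1.29 log units; beyond the scatter), which is large, whereas each single step shown is modest. Compound 1 gives no number, so the comparison with it yields only a floor, an at least 28-fold lower number from compound 1 to compound 4 (1.45 log units; beyond the scatter), and that floor rests on a limit: the limit of > 100000 nM in this assay, at which 1 of the 4 values shown sits.

As far as these compounds go, whether a longer chain than 4-carboxybutyl lowers the number further, or where the trend ends, remains open. Also open, from the compounds shown here alone, is whether a tetrazole in place of the carboxylic acid on the 4-carboxybutyl chain would keep the number of compound 4.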